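Swapping a methyl for methoxy on the acid side chain

The source may hold more compounds than are shown below. What is called first, only, known or untested is meant among the compounds shown, and "the series" means these compounds.

Measured so far in a functional assay on HFL1 cells for antagonist activity at sphingosine 1-phosphate receptor 2 (Homo sapiens), read by ELISA, with a stated time of 24 h; on this read-out lower numbers stand for stronger inhibition and higher numbers for weaker inhibition:
compound 1 `CC(C(=O)O)c1nn(Cc2cn3cc(OCC4CC4)c(C(F)(F)F)cc3n2)c2ccccc2c1=O` gives 5 nM;
compound 2 `CC(C)(C(=O)O)c1nn(Cc2cn3cc(OCC4CC4)c(Cl)cc3n2)c2ccccc2c1=O` gives 21 nM;
compound 3 `C[C@H](C(=O)O)n1nc(Cn2cc3cc(OCC4CC4)c(Cl)cc3n2)c2ccccc2c1=O` gives 3.5 nM.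

Among these three, compound 2 carries the highest number and so the weakest inhibition: compound 1 and compound 3 both sit below it by more than the usual scatter. Compound 4 `COC(C(=O)O)c1nn(Cc2cn3cc(OCC4CC4)c(Cl)cc3n2)c2ccccc2c1=O` has not yet been measured. It differs from compound 2 in a single place: carboxy(methoxy)methyl in place of 1-carboxy-1-methylethyl on an aromatic carbon. For the measured compounds named here, no pair of measured compounds isolates exactly this change, so its effect cannot be read from the existing numbers. A modest step is expected, most likely toward a lower number but possibly no larger than the scatter: a 1.8-fold lower number from compound 2 to compound 4 (0.24 log units; within the scatter). Compound 4 is therefore estimated at 12 nM, with a plausible range from 4 nM to 40 nM.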

Compound 4, half-maximal inhibitory concentration: 94 nM
Compound 4: middle estimate off by 7.8-fold (0.89 log units), on the low side, and the stated range ends below it.
By their numbers in this assay, from the lowest: compounds 3 and 1 (each within the scatter of the next); then compound 2; then compound 4.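

In this assay, putting carboxy(methoxy)methyl in place of 1-carboxy-1-methylethyl gives a 4.5-fold higher number from compound 2 to compound 4 (0.65 log units; beyond the scatter), a step beyond the scatter toward weaker inhibition. Both groups hold 6 heavy atoms and a carboxylic acid, so this position responds even when an oxygen simply replaces a carbon in a group of equal heavy-atom count. Nothing available explains the rise. Still open, as far as these compounds go, is whether the methoxy oxygen or the loss of a methyl on that carbon matters more. A 1-carboxyethyl group on the same core, or an ethoxy in place of the methoxy, would help separate the two.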